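A few compounds are considered here, and "the series" means these few. Any claim that something is new, unique, unknown or untested is made for them only; others in the source may bear on it.

Measured compounds:
- compound 1, `NNC(=O)CCc1ccncc1-c1ccc2ccccc2c1`: > 10000 nM
- compound 2, `CCOC(=O)/C=C/c1ccncc1-c1ccc2cc[nH]c2c1`: 7980 nM

Of the compounds shown here, two sharing the same pyridine-bearing core have been tested in a functional assay on MDA-MB-231 cells (Homo sapiens) for inhibition, read by sulforhodamine B assay, with a stated time of 72 h; a higher number here means a weaker inhibitor of growth, a lower number a stronger inhibitor of growth. Compound 1 gives > 10000 nM in this assay, and this is a limit of the assay rather than a measured number. All that is known of where compound 1 stands is therefore (the limit of > 10000 nM in this assay, at which 1 of the 2 values shown sits). Among the measured compounds shown here, compound 2, which carries a different aromatic group and an ester-bearing chain, gives 7980 nM in this assay; no step between compound 1 and compound 2 is drawn, as they differ in more than one place, and the two values show only that both are weak inhibitors of growth.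

Compound 3, `O=C(/C=C/c1ccncc1-c1ccc2ccccc2c1)NC1CC1`, is the compound not yet measured. It differs from compound 1 in one place: 2-(cyclopropylcarbamoyl)ethenyl in place of 2-(aminocarbamoyl)ethyl on an aromatic carbon. With compound 1 known only as a limit, the step of an at least 1.4-fold lower number from compound 1 to compound 3 (0.15 log units; that floor lies within the scatter) is expected to be modest, pointing toward somewhat stronger growth inhibition but possibly no further than the usual scatter. Compound 3 is estimated at 7000 nM in this assay, with a range from 2000 nM to 20000 nM.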

Compound 3, concentration for 50% growth inhibition: 8420 nM
For compound 3 the middle estimate is 1.2-fold (0.08 log units) below the measured one; the measured number falls inside the stated range.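

In this assay compound 1 gives > 10000 nM, which is a limit of the assay and not a number. Among the compounds shown here, putting 2-(cyclopropylcarbamoyl)ethenyl in place of 2-(aminocarbamoyl)ethyl, at the position opposite the ring nitrogen, yields a measured value on this core for the first time, but the change supports only an at least 1.1-fold lower number from compound 1 to compound 3 (0.07 log units; that floor lies within the scatter), so no real gain in growth inhibition can be claimed. The true size of the step cannot be read, and the only bound on it is set by a single value: the limit of > 10000 nM in this assay, at which 1 of the 3 values shown sits.

The swap alters several features at once, adding a double bond to the chain and a three-membered ring of carbon only while removing one nitrogen, and the compounds shown cannot separate what each of these contributes. They also leave open how a carboxylic acid, a simple amine or a longer chain at this position would behave, and whether any group here can give clearly stronger inhibition of growth.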